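The source may report more compounds than this note shows. Statements on the series, on what has been measured and on what is new or still open speak of the compounds shown alone.

Of the compounds shown here, three have been measured, and only one of them gave a number. In a functional assay on A-375 cells (Homo sapiens) for antiproliferative activity (a higher number here means a weaker inhibitor, a lower number a stronger inhibitor), compound 3, with the structure `O=C(Nc1ccc(-c2ccncc2)cc1)C1CCCN(Cc2ccc(F)c(F)c2)C1`, gives 600 nM. The remaining two values are limits of the assay rather than numbers. For compound 1, whose structure is `O=C(Nc1ccc(-c2cscn2)cc1)C1CN(Cc2ccc(F)c(F)c2)C1`, the result in this assay is a limit of > 20000 nM. For compound 2, whose structure is `O=C(Nc1ccc(-c2cscn2)cc1)C1CCCN(Cc2cccnc2)C1`, the result in this assay is likewise a limit of > 20000 nM. So compound 3 stands as the only compound with a numerical value, while the others sit at the limit of > 20000 nM in this assay, at which 2 of the 3 values shown sit; none of these pairs differ in a single place, so no step between them can be drawn.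

The next compound, compound 4, has the structure `O=C(Nc1ccc(-c2cc[nH]c2)cc1)C1CCCN(Cc2ccc(F)c(F)c2)C1`. It differs from compound 3 in one place: 1H-pyrrol-3-yl in place of pyridin-4-yl on an aromatic carbon. This swaps a six-membered ring carrying a hydrogen-bond acceptor for a five-membered ring carrying a hydrogen-bond donor, on the aromatic carbon para to the large group.

Within the data shown here, no measured step in this set shows what such a swap does, so the expectation rests only on the shape of the change. A modest loss of potency is expected, with the step from compound 3 to compound 4 estimated at a 2.5-fold higher number from compound 3 to compound 4 (0.40 log units; beyond the scatter). For compound 4 the estimate in this assay is 1500 nM, within a range from 300 nM to 8000 nM.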

Compound 4, half-maximal inhibitory concentration: 1420 nM
Compound 4: the middle estimate sits 1.1-fold (0.02 log units) above what was measured; the measured number falls inside the stated range.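

In this assay, among these compounds, the change gives a 2.4-fold higher number from compound 3 to compound 4 (0.37 log units; beyond the scatter), the first step in this set that can be read, as none of the earlier compounds differed from one another in a single place. Among the compounds shown here, it shows that this place, on an aromatic carbon para to a large group, can hold more than one kind of ring: compound 4, with 1H-pyrrol-3-yl, gives a real number rather than a limit, so pyridin-4-yl is not the only group here that does so. Ring size and the counts of hydrogen-bond donors and acceptors all change together in this one step, and nothing measured here accounts for its size.

The compounds shown leave open which part of the change matters, and a plain phenyl ring or a 1-methyl-1H-pyrrol-3-yl group in this place would help to pull those parts apart. As far as these compounds go, it also remains open how far this place accepts groups that are not aromatic rings at all, such as a small amine or a carboxylic acid.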